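Amide to urea and dichlorophenyl swap at the chain terminus

The source may hold more compounds than are shown below. What is called first, only, known or untested is meant among the compounds shown, and "the series" means these compounds.

Compound 1 `COc1cccc(-c2nn(-c3ccccc3)cc2-c2ccnc(NCCCNC(=O)c3cccc(C(F)(F)F)c3)c2)c1`: 3690 nM
Compound 2 `COc1cccc(-c2nn(-c3ccccc3)cc2-c2ccnc(NCCNC(=O)Nc3cccc(C(F)(F)F)c3)c2)c1`: 2130 nM

In a functional assay on K562 cells (Homo sapiens) for antiproliferative activity (on this read-out higher numbers stand for weaker inhibition of growth and lower numbers for stronger inhibition of growth), compound 1 gives 3690 nM and compound 2 gives 2130 nM. Compound 1 holds the higher of the two numbers, yet its gap to compound 2 lies within the scatter, so the two values cannot be ranked.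

Compound 3 `COc1cccc(-c2nn(-c3ccccc3)cc2-c2ccnc(NCCCNC(=O)Nc3ccc(Cl)c(Cl)c3)c2)c1` awaits measurement in this assay. It differs from compound 1 by (3,4-dichlorophenyl)amino in place of 3-(trifluoromethyl)phenyl on a carbonyl carbon. Among the compounds with values here, no single-point step between measured compounds is at hand, and compound 2 shows that a urea terminus sits within the scatter of compound 1. Compound 3 is therefore expected to show no step beyond the scatter, a 1.3-fold lower number from compound 1 to compound 3 (0.12 log units; within the scatter), with an estimate of 2800 nM spanning 900 nM to 9000 nM.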

Compound 3, concentration for 50% growth inhibition: 2380 nM
Estimate against measurement, compound 3: 1.2-fold (0.07 log units) above; the measured number falls inside the stated range.
By their numbers in this assay, from the lowest: compounds 2, 3 and 1 (each within the scatter of the next).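

In this assay, (3,4-dichlorophenyl)amino in place of 3-(trifluoromethyl)phenyl on a carbonyl carbon gives a 1.6-fold lower number from compound 1 to compound 3 (0.19 log units; within the scatter). This position therefore accepts the exchange of the amide terminus for a dichlorophenyl urea without a step beyond the scatter. Nothing available explains this result.

The linkage and the ring substituents change together here, so their separate contributions remain unresolved. A 3-(trifluoromethyl)phenyl urea on the same chain would separate them, and a terminal amine or carboxylic acid would test this position more widely.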